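Three side chains on a shared core, and a fourth

This account rests on a few compounds, and the source may have more. Where it says the series, first, only, none or still open, it means among the compounds named here.

Measured so far in a functional assay on MCF7 cells (Homo sapiens) for antiproliferative activity; on this read-out higher numbers stand for weaker inhibition and lower numbers for stronger inhibition:
- compound 1, `CC#CCCn1c(Cc2cc(OC)c(OC)c(OC)c2)nc2c(N)nc(F)nc21`, gives 37200 nM
- compound 2, `COc1cc(Cc2nc3c(N)nc(F)nc3n2CCOC(C)C)cc(OC)c1OC`, gives 15800 nM
- compound 3, `C#CCCCn1c(Cc2cc(OC)c(OC)c(OC)c2)nc2c(N)nc(F)nc21`, gives 11000 nM

All three share one core and differ only in the chain carried on the aromatic nitrogen. Compound 3 has the lowest of the three numbers, but its distance to compound 2 is within the scatter, so the two cannot be ranked; only compound 1 is clearly separated, as the steps of a 3.4-fold lower number from compound 1 to compound 3 (0.53 log units; beyond the scatter) and a 2.4-fold lower number from compound 1 to compound 2 (0.37 log units; beyond the scatter) show.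

Compound 4, `COCCn1c(Cc2cc(OC)c(OC)c(OC)c2)nc2c(N)nc(F)nc21`, is the next variation: methoxy in place of propargyl on a saturated chain carbon, two bonds along the chain from an aromatic nitrogen. Among the compounds with values here, the one measured step that comes closest is a 1.4-fold lower number from compound 2 to compound 3 (0.16 log units; within the scatter), where an oxygen-bearing group in the same place gave a number that did not differ beyond the scatter. A similar outcome is expected here, with some allowance for the shorter group. The estimated step is a 1.6-fold higher number from compound 3 to compound 4 (0.21 log units; within the scatter). For compound 4 the expected value in this assay is therefore 18000 nM, with a range from 7000 nM to 45000 nM.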

Compound 4, half-maximal inhibitory concentration: 64600 nM
Compound 4: middle estimate off by 3.6-fold (0.55 log units), on the low side; measured number outside the range, above it.
By their numbers in this assay, from the lowest: compounds 3 and 2 (each within the scatter of the next); then compounds 1 and 4 (each within the scatter of the next).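

In this assay, within the data shown here, the kind of group at the end of this chain matters more than the earlier compounds suggested: methoxy in place of propargyl, on a saturated chain carbon two bonds along the chain from an aromatic nitrogen, gives a 5.9-fold higher number from compound 3 to compound 4 (0.77 log units; beyond the scatter) in the number. Having an oxygen in the chain does not settle the result either, since methyl in place of isopropyl on that oxygen gives a 4.1-fold higher number from compound 2 to compound 4 (0.61 log units; beyond the scatter) in the number, whereas compound 2 had stayed within the scatter of compound 3. The remaining comparison, a 1.7-fold higher number from compound 1 to compound 4 (0.24 log units; within the scatter) in the number, lies within the scatter, so the chains of these two compounds cannot be ranked, and nothing measured here explains any of these steps.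

From the compounds shown here alone, with only four chains to compare, it remains open whether the number tracks the size of the end group, as methyl and isopropyl on the oxygen might hint, or something else about it. An amine or a carboxylic acid at the end of the chain, or a longer chain carrying the methoxy, could help separate these possibilities.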